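This account rests on a few compounds, and the source may have more. Where it says the series, first, only, none or still open, it means among the compounds named here.

Within the data shown here, compound 2 `O=[N+]([O-])c1ccccc1CSc1ncnc2c1ncn2[C@@H]1O[C@H](CO)[C@@H](O)[C@H]1O` gives 115 nM in an assay on isolated protein for inhibition of Equilibrative nucleoside transporter 1 (Homo sapiens) (on this read-out higher numbers stand for weaker inhibition and lower numbers for stronger inhibition), the higher of the two numbers measured so far, while compound 1 `OC[C@H]1O[C@@H](n2cnc3c(SCc4cccc(Cl)c4)ncnc32)[C@H](O)[C@@H]1O` gives 18.2 nM. Compound 3 `OC[C@H]1O[C@@H](n2cnc3c(SCc4ccc(Cl)cc4Cl)ncnc32)[C@H](O)[C@@H]1O` differs from compound 2 by 2,4-dichlorophenyl in place of 2-nitrophenyl on a saturated chain carbon bound to a sulfur. Among the measured compounds shown here, only one measured step bears on this change: a 6.3-fold higher number from compound 1 to compound 2 (0.80 log units; beyond the scatter), where a 3-chlorophenyl gave way to the 2-nitrophenyl. Since compound 3 again carries a chlorine-bearing ring at that place, its number is expected to move back down, by a 5.8-fold lower number from compound 2 to compound 3 (0.76 log units; beyond the scatter). Compound 3 is therefore estimated at 20 nM, with a likely range from 6 nM to 70 nM.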

Compound 3, inhibition constant: 4.37 nM
Beside the measured number, compound 3's estimate is 4.6-fold (0.66 log units) above it; the whole stated range lies above it.
By their numbers in this assay, from the lowest: compound 3; then compound 1; then compound 2.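

This position responds strongly to the ring it carries: 2,4-dichlorophenyl gives a 26-fold lower number from compound 2 to compound 3 (1.42 log units; beyond the scatter), and also a 4.2-fold lower number from compound 1 to compound 3 (0.62 log units; beyond the scatter), making compound 3 the strongest inhibitor of the three. A ring with two chlorines therefore outperforms the 3-chlorophenyl ring of compound 1, although the chlorine positions differ too, so the extra chlorine cannot be separated from their placement. Nothing measured here gives a reason for these steps. As far as these compounds go, it remains open whether an amine or a carboxylic acid on this ring would keep this strength. The effect of a longer chain on the sulfur is also unknown.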